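A few compounds are considered here, and "the series" means these few. Any claim that something is new, unique, unknown or untested is made for them only; others in the source may bear on it.

Compound 1, `CCOC(=O)c1oc2ccc(NS(=O)(=O)c3ccccc3C)cc2c1C`: 105000 nM in a functional assay on MCF7 cells (Homo sapiens) for antiproliferative activity, read by MTT assay, with a stated time of 72 h; on this read-out higher numbers stand for weaker inhibition and lower numbers for stronger inhibition.
Compound 2, `CCOC(=O)c1oc2ccc(NS(=O)(=O)c3ccccc3C(F)(F)F)cc2c1C`: 93900 nM in this assay.

Going by the values given here, compound 1 stands at the higher of the two numbers measured in this assay, but its only neighbour is compound 2, and the step of a 1.1-fold lower number from compound 1 to compound 2 (0.05 log units; within the scatter) lies within the scatter, so the two compounds cannot be ranked against each other. Compound 3, `CCOC(=O)c1oc2ccc(NS(=O)(=O)c3cccs3)cc2c1C`, is not yet measured. The change from compound 1 to compound 3 is thiophen-2-yl in place of 2-methylphenyl on a sulfonyl sulfur. Among the compounds with values here, the one measured step, a 1.1-fold lower number from compound 1 to compound 2 (0.05 log units; within the scatter), concerns a substituent exchanged on the ring that compound 3 no longer carries at all; it does not reproduce the replacement of one aromatic ring by another on the sulfonyl sulfur and therefore bears on the new step only loosely, showing merely that a change at that ring left the number unmoved. With nothing in the data pointing in either direction, the step of a 1.1-fold lower number from compound 1 to compound 3 (0.02 log units; within the scatter) is expected to stay within the scatter. Compound 3 is accordingly estimated at 100000 nM, with a range from 35000 nM to 280000 nM.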

Compound 3, half-maximal inhibitory concentration: 92300 nM
Compound 3: middle estimate off by 1.1-fold (0.03 log units), on the high side; the measured number falls inside the stated range.
By their numbers in this assay, from the lowest: compounds 3, 2 and 1 (each within the scatter of the next).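

Exchanging the whole aromatic ring on the sulfonyl sulfur, and not just a substituent on it, gives the step of a 1.1-fold lower number from compound 1 to compound 3 (0.06 log units; within the scatter) in this assay. The position therefore tolerates more than a swap of methyl for trifluoromethyl: a six-membered aromatic ring of carbon only can give way to a five-membered aromatic ring with a sulfur atom, and with 5 heavy atoms in place of 7, without the number leaving the scatter. No measurement of any other kind accompanies these numbers, so nothing explains why the number holds across this change.

What remains open is whether any group on the sulfonyl sulfur can take the number beyond the scatter, as all the groups shown there are aromatic rings without a charge; a saturated chain such as n-butyl, or a phenyl ring carrying an amine or a carboxylic acid, would test this. On these data alone, the ethyl ester of the shared core also stays the same throughout, so it is unknown how a carboxylic acid or an amide in its place would read in this assay.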